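Triazole-aryl series: fluoro to chloro on the phenyl

The compounds below may be only part of what the source reports. "The series", "measured", "known", "first", "only" and "open" are said of these compounds alone.

Measured so far in a functional assay on SW480 cells (Homo sapiens) for cytotoxicity, read by MTT assay, with a stated time of 4 days; a lower number here means a stronger inhibitor, a higher number a weaker inhibitor:
Compound 1 `Cc1ccc(S(=O)(=O)Oc2ccc3c(c2C)[C@H](Cn2cc(-c4ccccn4)nn2)[C@@]24CC(=O)[C@@](C)(CC[C@@H]32)C4)cc1` gives > 20000 nM, which is a limit of the assay and not a number.
Compound 2 `C=C1C(=O)[C@]23C[C@@]1(O)CC[C@H]2c1ccc(O)c(C)c1[C@@H]3Cn1cc(-c2ccccn2)nn1` gives 410 nM.
Compound 3 `C=C1C(=O)[C@]23C[C@@]1(O)CC[C@H]2c1ccc(O)c(C)c1[C@@H]3Cn1cc(-c2ccc(F)cc2)nn1` gives 250 nM.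

Compound 3 has the lowest of the two numbers shown; its nearest neighbour is compound 2, and the step of a 1.6-fold lower number from compound 2 to compound 3 (0.21 log units; within the scatter) lies within the scatter. Compound 1 sits at the limit of > 20000 nM in this assay, at which 1 of the 3 values shown sits, and yields no number.

Compound 4 `C=C1C(=O)[C@]23C[C@@]1(O)CC[C@H]2c1ccc(O)c(C)c1[C@@H]3Cn1cc(-c2ccc(Cl)cc2)nn1` differs from compound 3 only by chloro in place of fluoro on an aromatic carbon. No measured step covers a halogen swap at this place; the only step shown, a 1.6-fold lower number from compound 2 to compound 3 (0.21 log units; within the scatter), concerns the aromatic group on the triazole and is itself within the scatter. The data give no basis for a shift beyond the scatter in this assay in either direction. Compound 4 is therefore expected to sit close to compound 3, with an expected step of a 1.1-fold lower number from compound 3 to compound 4 (0.04 log units; within the scatter). The estimate for compound 4 is 230 nM, with a range from 100 nM to 550 nM.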

Compound 4, half-maximal inhibitory concentration: 280 nM
Estimate against measurement, compound 4: 1.2-fold (0.09 log units) below; the range from low to high includes it.
By their numbers in this assay, from the lowest: compounds 3, 4 and 2 (each within the scatter of the next). At a limit, above all of these: compound 1.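

In this assay, chloro in place of fluoro on the phenyl gives a 1.1-fold higher number from compound 3 to compound 4 (0.05 log units; within the scatter) and so leaves the read-out unchanged within the scatter, which shows that this place takes either halogen without a readable difference. The comparison with pyridin-2-yl gives a 1.5-fold lower number from compound 2 to compound 4 (0.17 log units; within the scatter) and, together with a 1.6-fold lower number from compound 2 to compound 3 (0.21 log units; within the scatter), shows that neither halogenated phenyl separates from the pyridin-2-yl group in this series. Nothing measured here bears on why these aromatic groups read alike.

Still open, from the compounds shown here alone, is whether a group of another kind on this phenyl, such as an amine, a carboxylic acid or a methoxy group, would give a step beyond the scatter. Also open, going by these compounds, is what a longer chain in place of the aromatic group on the triazole would give.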